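This account rests on a few compounds, and the source may have more. Where it says the series, first, only, none or still open, it means among the compounds named here.

Measured in an ADME assay on J774.A1 cells (Mus musculus) for cytotoxicity, read by MTT assay, with a stated time of 48 h; on this read-out higher numbers stand for lower toxicity in this test and lower numbers for higher toxicity in this test:
Compound 1 `COc1ccc(/C=C/C(=O)/C(C)=C/c2ccccc2)cc1`: 51000 nM
Compound 2 `COc1ccc(/C=C(\C)C(=O)/C=C/c2ccccc2)cc1`: 54000 nM

The value of compound 2, 54000 nM, lies within the usual scatter of the value of compound 1, 51000 nM, so the two numbers cannot be told apart. Compound 3 `COc1ccc(/C=C/C(=O)/C(C)=C/c2ccc(OC)cc2)cc1` differs from compound 2 by one structural change: methoxy in place of hydrogen on an aromatic carbon, para to a large group (methoxy in place of hydrogen on an aromatic carbon). Going by the values given here, no measured pair in this assay shows the effect of this change, so the data offer no direct guide. The expectation therefore starts from compound 2 at 54000 nM and foresees no change beyond the scatter, with only a slight lean towards a lower number. The expected step is a 1.2-fold lower number from compound 2 to compound 3 (0.08 log units; within the scatter), which would stay within the scatter. Compound 3 is estimated at 45000 nM, with an expected range from 20000 nM to 100000 nM.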

Compound 3, half-maximal cytotoxic concentration: 34100 nM
Compound 3: the middle estimate sits 1.3-fold (0.12 log units) above what was measured; low and high end bracket the measured number.
By their numbers in this assay, from the lowest: compounds 3, 1 and 2 (each within the scatter of the next).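

In this assay, going by these compounds alone, the earlier compounds offered no reading of methoxy in place of hydrogen on an aromatic carbon, para to a large group. The change can now be read twice, as a 1.6-fold lower number from compound 2 to compound 3 (0.20 log units; within the scatter) and as a 1.5-fold lower number from compound 1 to compound 3 (0.17 log units; within the scatter), and both steps lie within the scatter, so at this position the added methoxy gives a number that cannot be told apart from those of the compounds without it. Nothing measured here bears on this result.

On these data alone, it remains open whether another group at this position, such as an amine, a carboxylic acid or a longer alkoxy chain, would move the number beyond the scatter. With methoxy as the only substituent tried in this place, no trend across groups can be drawn.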